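The compounds below may be only part of what the source reports. "The series", "measured", "known", "first", "only" and "open" are said of these compounds alone.

Compound 1 `O=C(N/N=C/c1cccc(Br)c1)Nc1cc2c(Nc3ccc(F)c(Cl)c3)ncnc2cc1O[C@H]1CCOC1`: 12400 nM
Compound 2 `O=C(N/N=C/c1ccc(F)cc1Cl)Nc1cc2c(Nc3ccc(F)c(Cl)c3)ncnc2cc1O[C@H]1CCOC1`: 32200 nM
Compound 3 `COc1ccc(/C=N/NC(=O)Nc2cc3c(Nc4ccc(F)c(Cl)c4)ncnc3cc2O[C@H]2CCOC2)c(OC)c1OC`: 33800 nM

In a functional assay on MCF7 cells (Homo sapiens) for cytotoxicity, read by MTT assay, with a stated time of 72 h (a higher number here means a weaker inhibitor, a lower number a stronger inhibitor), compound 1 has the lowest of the three numbers. Compound 4 `O=C(N/N=C/c1ccc(O)c(Br)c1)Nc1cc2c(Nc3ccc(F)c(Cl)c3)ncnc2cc1O[C@H]1CCOC1` keeps its core but turns 3-bromophenyl into 3-bromo-4-hydroxyphenyl: hydroxy in place of hydrogen on an aromatic carbon. Among the measured compounds shown here, no measured step adds a hydroxy group, so the evidence is indirect. The two replacements of the 3-bromophenyl were modest, a 2.6-fold higher number from compound 1 to compound 2 (0.41 log units; beyond the scatter) and a 2.7-fold higher number from compound 1 to compound 3 (0.44 log units; beyond the scatter), while a 1.0-fold higher number from compound 2 to compound 3 (0.02 log units; within the scatter) stayed within the scatter. A similarly modest rise is therefore expected, though a step within the scatter remains possible. The expected change is a 1.5-fold higher number from compound 1 to compound 4 (0.16 log units; within the scatter). The estimate for compound 4 is 18000 nM, with an expected range of 7000 nM to 42000 nM.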

Compound 4, half-maximal inhibitory concentration: 2690 nM
Compound 4: the middle estimate sits 6.7-fold (0.83 log units) above what was measured; measured number outside the range, below it.
By their numbers in this assay, from the lowest: compound 4; then compound 1; then compounds 2 and 3 (each within the scatter of the next).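

In this assay, hydroxy in place of hydrogen on the aromatic carbon ortho to the bromo group gives a 4.6-fold lower number from compound 1 to compound 4 (0.66 log units; beyond the scatter), the only step from compound 1 shown here that lowers the number. The 3-bromo-4-hydroxyphenyl group also gives a 12-fold lower number from compound 2 to compound 4 (1.08 log units; beyond the scatter) and a 13-fold lower number from compound 3 to compound 4 (1.10 log units; beyond the scatter), so compound 4 is the strongest of the four. Nothing measured here accounts for this drop. The compounds shown leave open whether an amine or a carboxylic acid on the same carbon would lower the number as well. They also leave open whether hydroxy has this effect without the bromo group.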